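Swapping the Piperazine for a Triazole in a Weak Series

The compounds below may be only part of what the source reports. "The series", "measured", "known", "first", "only" and "open" are said of these compounds alone.

Measured compounds:
compound 1 `NS(=O)(=O)c1cc(-c2nnc(CN3CCN(c4ccccc4)CC3)o2)c(Cl)cc1SCc1ccccc1` — 100000 nM
compound 2 `NS(=O)(=O)c1cc(-c2nnc(CN3CCN(c4ccc(F)cc4)CC3)o2)c(Cl)cc1SCc1ccccc1` — 10000 nM
compound 3 `Cc1ccc(C)c(N2CCN(Cc3nnc(-c4cc(S(N)(=O)=O)c(SCc5ccccc5)cc4Cl)o3)CC2)c1` — 16000 nM

In a functional assay on HeLa cells (Homo sapiens) for cytotoxicity, read by MTT assay, with a stated time of 72 h (a higher number here means a weaker inhibitor, a lower number a stronger inhibitor), compound 1 gives 100000 nM, the highest number of the three, so it is the weakest inhibitor shown. Changing only the phenyl on the piperazine gave a 10-fold lower number from compound 1 to compound 2 (1.00 log units; beyond the scatter) and a 6.3-fold lower number from compound 1 to compound 3 (0.80 log units; beyond the scatter), both modest gains. Compound 2 and compound 3 lie within the scatter of each other (a 1.6-fold higher number from compound 2 to compound 3 (0.20 log units; within the scatter)).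

Compound 4 `NS(=O)(=O)c1cc(-c2nnc(Cn3cc(-c4ccccc4)nn3)o2)c(Cl)cc1SCc1ccccc1` differs from compound 1 by 4-phenyl-1H-1,2,3-triazol-1-yl in place of 4-phenylpiperazin-1-yl on a saturated chain carbon bound to an aromatic carbon. Going by the values given here, no measured step bears directly on this: the two known steps keep the piperazine and alter only the phenyl attached to it, whereas here the whole saturated ring is exchanged for an aromatic one. Among the compounds with values here, the only guidance is that both changes made from compound 1 lowered the number, and that compound 1 already sits at the high end. A modest drop in this assay is therefore expected, with wide uncertainty.

Compound 4 is expected to give 40000 nM, within 8000 nM to 120000 nM. That estimate means a 2.5-fold lower number from compound 1 to compound 4 (0.40 log units; beyond the scatter).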

Compound 4, half-maximal inhibitory concentration: 7000 nM
Compound 4: middle estimate off by 5.7-fold (0.76 log units), on the high side; measured number below the stated range.
By their numbers in this assay, from the lowest: compounds 4, 2 and 3 (each within the scatter of the next, the first and the last beyond it); then compound 1.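

Exchanging the whole 4-phenylpiperazin-1-yl for 4-phenyl-1H-1,2,3-triazol-1-yl in this assay gives a 14-fold lower number from compound 1 to compound 4 (1.15 log units; beyond the scatter), so this position accepts more than changes to the phenyl. The earlier compounds shown here all kept the piperazine, so they could not show that a saturated ring is unnecessary here for a lower number; a five-membered aromatic ring with three hetero atoms serves in its place. Nothing measured here explains the drop.

Still open, as far as these compounds go, is whether the phenyl on the triazole is needed at all, which a triazole carrying an amine or a carboxylic acid in its place could test. From the compounds shown here alone, it is also open whether fluoro, which lowered the number on the phenyl of the piperazine series, would do the same on the triazole series.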